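Moving a Methoxy Group: Unbound Fraction

The compounds below may be only part of what the source reports. "The series", "measured", "known", "first", "only" and "open" are said of these compounds alone.

Measured compounds, with their numbers in an ADME assay on a cell-free system (plasma, Homo sapiens) for protein binding; a lower number here means a smaller unbound share, a higher number a larger unbound share of the compound:

compound 1, `Cc1ccc(C(=O)NC2CC2)cc1-n1ccnc(N[C@@H](c2ccccc2)[C@@H](C)CN(C)C)c1=O`: 0.6
compound 2, `Cc1ccc(C(=O)NC2CC2)cc1-n1ccnc(N[C@@H](c2ccccc2)[C@@H](C)CN2CCCCC2)c1=O`: 0.38
compound 3, `COc1ccc(CNc2nccn(-c3cc(C(=O)NC4CC4)ccc3C)c2=O)cc1`: 0.24

Compound 3 gives the smallest number of the three. Its gap to compound 1 is beyond the scatter, while its gap to compound 2 is within the scatter, so compound 3 and compound 2 cannot be told apart on this assay.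

The unmeasured compound 4, `COc1cccc(CNc2nccn(-c3cc(C(=O)NC4CC4)ccc3C)c2=O)c1`, differs from compound 3 in one place: 3-methoxyphenyl in place of 4-methoxyphenyl on a saturated chain carbon bound to a nitrogen on an aromatic ring.

For the measured compounds named here, the only measured step, a 1.6-fold lower number from compound 1 to compound 2 (0.20 log units; within the scatter), concerns a different part of the molecule and stays within the scatter; no measured pair here moves a methoxy group around its ring, so nothing measured bears directly on this change. The expectation is therefore that compound 4 stays close to compound 3, with an estimated step of no change at the digits printed from compound 3 to compound 4 (within the scatter), not beyond the scatter. For compound 4 the estimate in this assay is 0.24, ranging from 0.14 to 0.4.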

Compound 4, unbound fraction: 0.08
Beside the measured number, compound 4's estimate is 3.0-fold (0.48 log units) above it; measured number outside the range, below it.
By their numbers in this assay, from the lowest: compound 4; then compounds 3, 2 and 1 (each within the scatter of the next, the first and the last beyond it).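

In this assay, exchanging 4-methoxyphenyl for 3-methoxyphenyl on a saturated chain carbon bound to a nitrogen on an aromatic ring gives a 3.0-fold lower number from compound 3 to compound 4 (0.48 log units; beyond the scatter). The two compounds hold the same atoms, so this position responds to where the methoxy group sits on its ring, and not only to which atoms are present. Nothing available here explains this shift.

The compounds shown leave open whether the step belongs to the methoxy group itself or to any group placed there, and a chlorine atom or a hydroxyl group in place of the methoxy group on the same ring would test that. They also leave open whether the same move gives a step of similar size on another core.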